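The compounds below may be only part of what the source reports. "The series", "measured", "known", "first", "only" and "open" are said of these compounds alone.

Measured so far:
compound 1 `C=C1C(=O)[C@@]23C(=O)OC[C@]4([C@@H](OC(C)=O)CCC(C)(C)[C@H]4C=O)[C@@H]2CC[C@@H]1[C@H]3O` – 75400 nM
compound 2 `C=C1C(=O)[C@@]23C(=O)OC[C@]4(C(=O)CCC(C)(C)[C@H]4C=O)[C@@H]2CC[C@@H]1[C@H]3OC(=O)c1ccc(C)cc1` – 1540 nM
compound 3 `C=C1C(=O)[C@@]23C(=O)OC[C@]4(C(=O)CCC(C)(C)[C@H]4C=O)[C@@H]2CC[C@@H]1[C@H]3OC(=O)c1ccc(OC)cc1` – 2800 nM

In a functional assay on Bel-7402 cells (Homo sapiens) for cytotoxicity, read by MTT assay, with a stated time of 72 h (a higher number here means a weaker inhibitor, a lower number a stronger inhibitor), compound 3 gives 2800 nM (within the scatter of compound 2), far from compound 1 at 75400 nM and its different substitution.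

Compound 4 `C=C1C(=O)[C@@]23C(=O)OC[C@]4(C(=O)CCC(C)(C)[C@H]4C=O)[C@@H]2CC[C@@H]1[C@H]3OC(=O)c1ccccc1F` carries 2-fluorophenyl in place of 4-methoxyphenyl on a carbonyl carbon.

Going by the values given here, the only measured step at this group, a 1.8-fold higher number from compound 2 to compound 3 (0.26 log units; within the scatter) (methoxy in place of methyl on an aromatic carbon), stayed within the scatter. Among the compounds with values here, no fluorinated compound has been measured yet, so no clear direction can be expected. The expected step is a 1.3-fold lower number from compound 3 to compound 4 (0.10 log units; within the scatter) in this assay and is not expected to exceed the scatter.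

For compound 4 the estimated value is 2200 nM with an expected range of 800 nM to 6000 nM.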

Compound 4, half-maximal inhibitory concentration: 3950 nM
Beside the measured number, compound 4's estimate is 1.8-fold (0.25 log units) below it; measured number inside the range.
By their numbers in this assay, from the lowest: compounds 2, 3 and 4 (each within the scatter of the next, the first and the last beyond it); then compound 1.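

In this assay, replacing the group on this carbonyl carbon gives a 1.4-fold higher number from compound 3 to compound 4 (0.15 log units; within the scatter) and so does not separate 2-fluorophenyl from 4-methoxyphenyl. Set against 4-methylphenyl, the same group gives a 2.6-fold higher number from compound 2 to compound 4 (0.41 log units; beyond the scatter) and this is the first step at this position to pass the scatter, though only modestly. No measurement on hand explains this step.

The compounds shown leave open how 4-fluorophenyl would compare with 2-fluorophenyl here. They also leave open how a phenyl ring bearing an amine or a carboxylic acid would fare on this carbonyl carbon.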